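The compounds below may be only part of what the source reports. "The series", "measured", "known", "first", "only" and "open" are said of these compounds alone.

Compound 1, `Cc1ccc(NC(=O)N[C@H]2CC[C@H](Oc3ccc(F)cc3)CC2)cc1`, in a functional assay on CRL2813 cells (Homo sapiens) for cytotoxicity, read by sulforhodamine B assay, with a stated time of 5 days; a higher number here means a weaker inhibitor, a lower number a stronger inhibitor: > 20000 nM
Compound 2, `CSc1ccccc1NC(=O)N[C@H]1CC[C@H](Oc2ccc(F)cc2)CC1`, in this assay: > 20000 nM
Compound 3, `O=C(Nc1ccc(Cl)cc1)N[C@H]1CC[C@H](Oc2ccc(F)cc2)CC1`, in this assay: > 20000 nM

Each of these three values is a limit of this assay and not a number. Compound 3 therefore stands at the limit of this assay, and the two further values shown are limits as well. Compound 3 cannot be ranked against compound 1 or compound 2: the steps a step that the two limits leave unreadable from compound 1 to compound 3 and a step that the two limits leave unreadable from compound 2 to compound 3, like a step that the two limits leave unreadable from compound 1 to compound 2, cannot be read in size, since all three values sit at the limit of > 20000 nM in this assay, at which 3 of the 3 values shown sit.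

Compound 4, `O=C(Nc1ccc([N+](=O)[O-])cc1)N[C@H]1CC[C@H](Oc2ccc(F)cc2)CC1`, differs from compound 3 by nitro in place of chloro on an aromatic carbon. Among the compounds with values here, the steps that bear on this change are those leading from compound 1 and from compound 2 into compound 3, and both are unreadable; neither the methyl variant, the 2-(methylsulfanyl)phenyl variant nor the chloro variant gave a number in this assay. No measured step therefore sets a direction or a size for the nitro substitution, and on these compounds alone compound 4 is expected to sit at the same limit of this assay. For compound 4 the estimate is 25000 nM, with a range from 8000 nM to 80000 nM. The step that this estimate means, a step that the limit leaves unreadable from compound 3 to compound 4, is expected to lie within the scatter.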

Compound 4, half-maximal inhibitory concentration: 2300 nM
Compound 4: the middle estimate sits 11-fold (1.04 log units) above what was measured, outside the stated range (below it).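

At this position, para to a large group, nitro in place of chloro gives an at least 8.6-fold lower number from compound 3 to compound 4 (0.93 log units; beyond the scatter), so a change in this one substituent is enough to bring a measured number into this assay. The comparisons with the other two compounds point the same way, with an at least 8.6-fold lower number from compound 1 to compound 4 (0.93 log units; beyond the scatter) for nitro in place of methyl and an at least 8.6-fold lower number from compound 2 to compound 4 (0.93 log units; beyond the scatter) for 4-nitrophenyl in place of 2-(methylsulfanyl)phenyl on the amide-type nitrogen. All three sizes are lower bounds, as compound 4 is the only one of the four with a number and the other three remain at a limit of the assay: the limit of > 20000 nM in this assay, at which 3 of the 4 values shown sit.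

Among the compounds shown, only methyl, chloro and nitro stand at this position on the phenyl group, so it remains open whether an amine, a nitrile or a carboxylic acid there would also give a number instead of a limit. On these data alone, it also remains open whether nitro would give a similar step if the rest of the core of compound 4 were changed.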